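Ethyl to isopropyl ester on the shared core

A few compounds are considered here, and "the series" means these few. Any claim that something is new, unique, unknown or untested is made for them only; others in the source may bear on it.

Measured:
compound 1, `CCOC(=O)C1=C(C)NC(C)=C(C(=O)OCC)C1c1csc(-c2ccc(Cl)cc2)n1`: 3650 nM
compound 2, `CC1=C(C(=O)OC(C)c2ccccc2)C(c2csc(-c3ccc(Cl)cc3)n2)C(C(=O)OC(C)c2ccccc2)=C(C)N1`: 400000 nM

In an assay on isolated protein for antagonist activity at Voltage-dependent L-type calcium channel subunit alpha-1C (Cavia porcellus), with a stated time of 15 min (on this read-out lower numbers stand for stronger inhibition and higher numbers for weaker inhibition), compound 1 gives the lowest of the two numbers; the nearest, compound 2, sits at a number beyond the scatter of it. Compound 3, `CCOC(=O)C1=C(C)NC(C)=C(C(=O)OC(C)C)C1c1csc(-c2ccc(Cl)cc2)n1`, is not yet measured. It differs from compound 1 by methyl in place of hydrogen on a saturated chain carbon bound to an oxygen next to a carbonyl group and a saturated chain carbon. Within the data shown here, no step between measured compounds of this kind exists, so the expected step of a 1.5-fold lower number from compound 1 to compound 3 (0.16 log units; within the scatter) in this assay is small, likely not beyond the scatter. Compound 3 is estimated at 2500 nM, within 800 nM to 8000 nM.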

Compound 3, half-maximal inhibitory concentration: 2550 nM
Beside the measured number, compound 3's estimate is 1.0-fold (0.01 log units) below it; the range from low to high includes it.
By their numbers in this assay, from the lowest: compounds 3 and 1 (each within the scatter of the next); then compound 2.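

In this assay, ethyl to isopropyl on this ester gives a 1.4-fold lower number from compound 1 to compound 3 (0.16 log units; within the scatter), so this position takes the added methyl on a saturated chain carbon bound to an oxygen with no change beyond the scatter. The shared core therefore keeps its activity in this assay with either the ethoxycarbonyl or the isopropoxycarbonyl group at this place. Nothing available explains this result.

On these data alone, whether a tert-butyl group or a longer chain on this oxygen would also stay within the scatter of compound 1 remains open. So does the effect of a carboxylic acid or an amide in place of this ester.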